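The source may report more compounds than this note shows. Statements on the series, on what has been measured and on what is new or still open speak of the compounds shown alone.

Compound 1 `CCOC(=O)N(C)C(C)C#CCN1CCCC1` and compound 2 `CCOC(=O)N(C)C(C)C#CCn1ccnc1` share a core and differ in one place. In a functional assay on the whole organism for antagonist activity, with Mus musculus as the target (a lower number here means that less compound is needed, a higher number that more compound is needed for the effect), compound 1 gives 97 mg/kg, while compound 2 gives 54 mg/kg; the step of a 1.8-fold lower number from compound 1 to compound 2 (0.25 log units; within the scatter) corresponds to the change (1H-imidazol-1-yl in place of pyrrolidin-1-yl on a saturated chain carbon bound to a triple-bonded carbon). Compound 3 `CN(C)C(=O)N(C)CC#CCN1CCCC1` is built on a different core, and the difference between the two cores is not broken down here; in this assay compound 3 gives 6.6 mg/kg, the lowest number of the three and beyond the scatter from both others. Compound 4 `CN(C)C(=O)N(C)CC#CCn1ccnc1` is obtained from compound 3 by the same change, (1H-imidazol-1-yl in place of pyrrolidin-1-yl on a saturated chain carbon bound to a triple-bonded carbon). Because the earlier step of a 1.8-fold lower number from compound 1 to compound 2 (0.25 log units; within the scatter) stayed within the scatter, a similarly small step is expected here, a 1.3-fold lower number from compound 3 to compound 4 (0.12 log units; within the scatter). Compound 4 is therefore estimated at 5 mg/kg, with a likely range from 2.2 mg/kg to 11 mg/kg.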

Compound 4, dose for half-maximal effect: 11.8 mg/kg
Beside the measured number, compound 4's estimate is 2.4-fold (0.37 log units) below it, and the stated range ends below it.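

In this assay, placing 1H-imidazol-1-yl where pyrrolidin-1-yl stood gives a 1.8-fold higher number from compound 3 to compound 4 (0.25 log units; within the scatter). Set beside the earlier step, this shows that the change does not carry over as one constant shift from core to core: the same change on two cores in this assay, a 1.8-fold lower number (0.25 log units; within the scatter) from compound 1 to compound 2 and a 1.8-fold higher number (0.25 log units; within the scatter) from compound 3 to compound 4, 3.2-fold (0.51 log units) apart, beyond the scatter of two such steps. Each step taken alone stays within the scatter, however, so neither core on its own shows a clear effect of the change, and two cores do not reveal what sets the gap between the steps.

The compounds shown leave open how a piperidin-1-yl or a dimethylamino group would behave on a saturated chain carbon bound to a triple-bonded carbon. They also leave open whether the two steps would differ in the same way on a third core.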